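A few compounds are considered here, and "the series" means these few. Any claim that something is new, unique, unknown or untested is made for them only; others in the source may bear on it.

Going by the values given here, in an assay on isolated protein for inhibition of Long-chain-fatty-acid--CoA ligase 1 (Mus musculus), read by mass spectrometry, with a stated time of 90 min, in the presence of a further agent that is not named here (on this read-out lower numbers stand for stronger inhibition and higher numbers for weaker inhibition), compound 1 `Cc1cccc(Cc2nc3cc(O[C@H]4CC[C@@H](C(=O)O)CC4)ccc3n2C)c1` gives 30 nM, the lowest of the three numbers measured so far. Compound 2 `Cc1ccc(Cc2nc3cc(O[C@H]4CC[C@@H](C(=O)O)CC4)ccc3n2C)cc1` gives 80 nM in this assay, and compound 3 `Cc1cccc(Cc2nc3cc(O[C@H]4CC[C@@H](C(=O)O)CC4)cc(Cl)c3n2C)c1` gives 170 nM. The two steps already seen, a 2.7-fold higher number from compound 1 to compound 2 (0.43 log units; beyond the scatter) and a 5.7-fold higher number from compound 1 to compound 3 (0.75 log units; beyond the scatter), both change the aromatic parts of the molecule and leave the carboxy untouched, so neither bears on the change to compound 4 `Cc1cccc(Cc2nc3cc(O[C@H]4CC[C@@H](c5noc(=O)[nH]5)CC4)ccc3n2C)c1`, in which (a group of 6 heavy atoms (2 carbon, 2 nitrogen, 2 oxygen; one five-membered aromatic ring with 3 hetero atoms) in place of a group of 3 heavy atoms (1 carbon, 2 oxygen; no ring), on a saturated ring carbon). Nothing measured here tells how the carboxy position tolerates change; both the leaving and the entering group carry a hydrogen-bond donor, so a step of modest size in either direction, or none beyond the scatter, is expected. The step expected is a 1.7-fold higher number from compound 1 to compound 4 (0.22 log units; within the scatter). Compound 4 is estimated to give 50 nM, within a range from 12 nM to 200 nM.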

Compound 4, half-maximal inhibitory concentration: 100 nM
For compound 4 the middle estimate is 2.0-fold (0.30 log units) below the measured one, within the range that was stated.
By their numbers in this assay, from the lowest: compound 1; then compounds 2, 4 and 3 (each within the scatter of the next, the first and the last beyond it).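

Replacing the carboxy on this saturated ring carbon with the five-membered aromatic ring with 3 hetero atoms gives a 3.3-fold higher number from compound 1 to compound 4 (0.52 log units; beyond the scatter) in this assay, so this change costs some inhibition. Even so, compound 4 still gives 100 nM, which shows that a carboxy at this place is not required for inhibition in the nanomolar range. No measurement here accounts for the size of this step.

As far as these compounds go, whether a tetrazole ring or a primary amide on the same carbon would give a lower or higher number remains open. So does the result of a plain hydrogen there.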